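Adding cyano to the benzyl group of compound 3

The source may report more compounds than this note shows. Statements on the series, on what has been measured and on what is new or still open speak of the compounds shown alone.

In a functional assay on a cell-free system (plasma, Oryctolagus cuniculus) for inhibition, with stated times of 5 min, 1 min and 6 min (on this read-out lower numbers stand for stronger inhibition and higher numbers for weaker inhibition), compound 1 `COn1c(-c2cccc(C#N)c2)nc(C)c1C(=O)O` gives 7990 nM, compound 2 `C=CCOn1c(-c2cccc(C#N)c2)nc(C)c1C(=O)O` gives 6350 nM and compound 3 `Cc1nc(-c2cccc(C#N)c2)n(OCc2ccccc2)c1C(=O)O` gives 6240 nM. Compound 3 therefore stands level with the other two, all within the scatter.

Compound 4 `Cc1nc(-c2cccc(C#N)c2)n(OCc2ccc(C#N)cc2)c1C(=O)O` changes the benzyl group of compound 3 to 4-cyanobenzyl: cyano in place of hydrogen on an aromatic carbon. Going by the values given here, no measured step covers this change on the aromatic ring. The closest evidence is the substituent swaps on the chain carbon: a 1.3-fold lower number from compound 1 to compound 2 (0.10 log units; within the scatter), a 1.3-fold lower number from compound 1 to compound 3 (0.11 log units; within the scatter) and a 1.0-fold lower number from compound 2 to compound 3 (0.01 log units; within the scatter). All are small, so no step beyond the scatter is expected in this assay. The expected change is a 1.1-fold lower number from compound 3 to compound 4 (0.05 log units; within the scatter). Compound 4 is estimated at 5500 nM, with an expected range of 2500 nM to 12000 nM.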

Compound 4, half-maximal inhibitory concentration: 3880 nM
Compound 4: the middle estimate sits 1.4-fold (0.15 log units) above what was measured; the measured number falls inside the stated range.
By their numbers in this assay, from the lowest: compounds 4, 3, 2 and 1 (each within the scatter of the next, the first and the last beyond it).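

In this assay, going by these compounds alone, the ring carbon para to a large group carries cyano with a 1.6-fold lower number from compound 3 to compound 4 (0.21 log units; within the scatter) and, measured against the vinyl group, with a 1.6-fold lower number from compound 2 to compound 4 (0.21 log units; within the scatter), so the aromatic ring of the benzyl group accepts a nitrile here with no step past the scatter. Only a 2.1-fold lower number from compound 1 to compound 4 (0.31 log units; beyond the scatter), set against the methoxy end of the series, passes the scatter, and modestly. Nothing measured accounts for these numbers. Open, going by these compounds, is how an amine, a carboxylic acid or a methoxy group on this same ring carbon would read.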